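Moving the methoxy group: from compound 3 to compound 4

The source may report more compounds than this note shows. Statements on the series, on what has been measured and on what is new or still open speak of the compounds shown alone.

Compound 1, `CCOC(=O)c1cnc(-c2ccncc2)nc1NN1C(=O)C=C(C)C1=O`: 6000 nM
Compound 2, `CCOC(=O)c1cnc(-c2cc(Cl)nc(Cl)c2)nc1NN1C(=O)C=C(C)C1=O`: 2000 nM
Compound 3, `CCOC(=O)c1cnc(-c2ccc(OC)cc2)nc1NN1C(=O)C=C(C)C1=O`: 900 nM

Three compounds on a shared core, differing only in the aryl group, have been tested in a functional assay on Jurkat cells for inhibition of nuclear factor NF-kappa-B complex (Homo sapiens); on this read-out lower numbers stand for stronger inhibition and higher numbers for weaker inhibition. Compound 3 gives the lowest number of the three: the change from compound 1 gave a 6.7-fold lower number from compound 1 to compound 3 (0.82 log units; beyond the scatter), and from compound 2 it gave a 2.2-fold lower number from compound 2 to compound 3 (0.35 log units; beyond the scatter), both beyond the scatter, so compound 3 stands as the strongest inhibitor so far.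

Compound 4, `CCOC(=O)c1cnc(-c2cccc(OC)c2)nc1NN1C(=O)C=C(C)C1=O`, is its positional isomer: 3-methoxyphenyl in place of 4-methoxyphenyl on an aromatic carbon. Among the measured compounds shown here, no measured step moves a substituent around the aryl ring, so the steps that bear on it only loosely are the two aryl swaps above, each modest in size. A shift of similar or smaller size is therefore expected, most likely toward a higher number, with the estimated step of a 2.0-fold higher number from compound 3 to compound 4 (0.30 log units; within the scatter). On that basis compound 4 is expected to give about 1800 nM in this assay , within a range of 600 nM to 5500 nM.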

Compound 4, half-maximal inhibitory concentration: 5000 nM
Compound 4: middle estimate off by 2.8-fold (0.44 log units), on the low side; low and high end bracket the measured number.
By their numbers in this assay, from the lowest: compound 3; then compound 2; then compounds 4 and 1 (each within the scatter of the next).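

In this assay, moving the methoxy group alone, with the same atoms joined differently, gives a 5.6-fold higher number from compound 3 to compound 4 (0.74 log units; beyond the scatter), so the standing of compound 3 belongs to the 4-methoxyphenyl group and not to any methoxyphenyl group at this aromatic carbon. The 3-methoxyphenyl group also loses out to the 2,6-dichloropyridin-4-yl group, with a 2.5-fold higher number from compound 2 to compound 4 (0.40 log units; beyond the scatter), and it cannot be told apart from the pyridin-4-yl group, with a 1.2-fold lower number from compound 1 to compound 4 (0.08 log units; within the scatter). Nothing at hand gives a reason for this difference between the two isomers.

The compounds shown leave open whether the gain depends on the methoxy group itself, or whether a 4-ethoxyphenyl, 4-hydroxyphenyl or 4-aminophenyl group would match or pass compound 3. They also leave open whether this ranking of aryl groups would hold if a carboxylic acid replaced the ethoxycarbonyl group.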